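Dropping a Methyl Group on a Shared Aryl Ring

The source may hold more compounds than are shown below. What is called first, only, known or untested is meant among the compounds shown, and "the series" means these compounds.

Compound 1 `COc1cc(OC)c2sc(-c3ccc(N/C=C\C(=O)c4ccc(OC)c(O)c4)c(C)c3)nc2c1` and compound 2 `COc1cc(OC)c2sc(-c3ccc(N/C=C\C(=O)c4ccc(OC)c(O)c4)cc3)nc2c1` share one core and differ in a single place. In a functional assay on A549 cells (Homo sapiens) for antiproliferative activity, read by sulforhodamine B assay, with a stated time of 48 h (a higher number here means a weaker inhibitor, a lower number a stronger inhibitor), compound 1 gives 14300 nM, while compound 2 gives 10600 nM. The change between them is hydrogen in place of methyl on an aromatic carbon, and it made a step of a 1.3-fold lower number from compound 1 to compound 2 (0.13 log units; within the scatter), so the two numbers cannot be told apart with confidence.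

Compound 3 `COc1ccc2nc(-c3ccc(N/C=C\C(=O)c4cc(OC)c(OC)c(OC)c4Br)c(C)c3)sc2c1` is built on a different core; the difference between the two cores is not broken down here. In this assay compound 3 gives 6400 nM.

Compound 4 `COc1ccc2nc(-c3ccc(N/C=C\C(=O)c4cc(OC)c(OC)c(OC)c4Br)cc3)sc2c1` has not yet been measured. It differs from compound 3 by hydrogen in place of methyl on an aromatic carbon. The surroundings of that carbon are not described in the same words for both pairs: in compound 1 it is meta to a large group, in compound 3 it is meta to a 6-methoxy-1,3-benzothiazol-2-yl group. The change is therefore the same kind of change, not the same.

The step is expected to be a 1.3-fold lower number from compound 3 to compound 4 (0.11 log units; within the scatter), because the earlier pair showed a 1.3-fold lower number from compound 1 to compound 2 (0.13 log units; within the scatter), a step that stayed within the usual scatter. Among the compounds with values here, with only one such example, the expectation carries real uncertainty. Compound 4 is expected to give 5000 nM in this assay, with a plausible range from 2500 nM to 10000 nM.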

Compound 4, half-maximal inhibitory concentration: 6000 nM
The estimate for compound 4 lay 1.2-fold (0.08 log units) below the measured number; measured number inside the range.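

On the second core, putting hydrogen in place of the methyl group gave a 1.1-fold lower number from compound 3 to compound 4 (0.03 log units; within the scatter), so in this assay compound 3 and compound 4 cannot be told apart. Set beside the earlier pair, the change carries over from one core to the other in the same way, with neither step large enough to read as a real effect and no real gap between the two: the same change on two cores in this assay, a 1.3-fold lower number (0.13 log units; within the scatter) from compound 1 to compound 2 and a 1.1-fold lower number (0.03 log units; within the scatter) from compound 3 to compound 4, 1.3-fold (0.10 log units) apart, within the scatter of two such steps. This shows that in these two pairs, and in this one cell assay, the methyl group on the shared aryl ring made no difference that can be read, but two pairs make no general rule, and the numbers do not show that the methyl group would be equally silent on another core or in another test.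

The compounds shown carry only methyl or hydrogen at this place, which leaves open whether an ethyl chain, an amine or a carboxylic acid on that same carbon would move the number. On these data alone, the contribution of each core also stays open, as compound 2 and compound 4 differ in more than one place and cannot be compared directly.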